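A few compounds are considered here, and "the series" means these few. Any claim that something is new, unique, unknown or untested is made for them only; others in the source may bear on it.

Measured so far:
compound 1 `CC(C)CC1(CCCCN2CCN(c3cccc(Cl)c3)CC2)C(=O)Nc2ccccc21` — 1.8 nM
compound 2 `O=C1Nc2ccc(F)cc2C1CCCCN1CCN(c2cccc(Cl)c2)CC1` — 1.96 nM

In an assay on CHO cells for displacement of a labelled ligand from 5-hydroxytryptamine receptor 7 (Homo sapiens) (a higher number here means a weaker inhibitor, a lower number a stronger inhibitor), compound 1 gives 1.8 nM. In this assay compound 2 gives 1.96 nM, and this number and that of compound 1 lie within the scatter of each other, so the two cannot be told apart on these data. Compound 3 `O=C1Nc2ccccc2C1CCCCN1CCN(c2cccc(Cl)c2)CC1` is not yet measured; it differs from compound 2 by hydrogen in place of fluoro on an aromatic carbon. Within the data shown here, no measured pair shows the effect of such a change, so only a modest step is expected, a 1.3-fold higher number from compound 2 to compound 3 (0.12 log units; within the scatter), towards a somewhat higher number and not clearly beyond the scatter. Compound 3 is therefore estimated at 2.6 nM, with a range from 1 nM to 7 nM.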

Compound 3, inhibition constant: 0.49 nM
Compound 3: the middle estimate sits 5.3-fold (0.72 log units) above what was measured; the whole stated range lies above it.
By their numbers in this assay, from the lowest: compound 3; then compounds 1 and 2 (each within the scatter of the next).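

In this assay, hydrogen in place of fluoro on the aromatic carbon gives a 4.0-fold lower number from compound 2 to compound 3 (0.60 log units; beyond the scatter), so this position responds to the change, and hydrogen is the better of the two groups seen there. Hydrogen in place of isobutyl on the saturated ring carbon likewise gives a 3.7-fold lower number from compound 1 to compound 3 (0.57 log units; beyond the scatter), so neither substituent matches compound 3 in this assay. Nothing available explains either step.

As far as these compounds go, whether a methoxy group or an amine on that aromatic carbon would match hydrogen remains open. So does whether a methyl group on the saturated ring carbon would.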